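The source may report more compounds than this note shows. Statements on the series, on what has been measured and on what is new or still open speak of the compounds shown alone.

Measured compounds:
compound 1: `COc1ncc(-c2ccc3nc(NC(=O)N(C)C)nn3c2)cc1NS(=O)(=O)c1ccc(F)cc1`, 1560 nM
compound 2: `COc1ncc(-c2ccc3nc(NC(=O)NCCN4CCCC4)nn3c2)cc1NS(=O)(=O)c1ccc(F)cc1`, 380 nM

Both numbers come from a functional assay on MCF7 cells (Homo sapiens) for cytotoxicity, read by MTT assay, with a stated time of 72 h; on this read-out higher numbers stand for weaker inhibition and lower numbers for stronger inhibition. Among the measured compounds shown here, compound 2 stands lowest of the two, the nearest being compound 1; the single step between them, a 4.1-fold lower number from compound 1 to compound 2 (0.61 log units; beyond the scatter), is modest but beyond the scatter.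

Compound 3, `COc1ncc(-c2ccc3nc(NC(=O)NCC(=O)N4CCOCC4)nn3c2)cc1NS(=O)(=O)c1ccc(F)cc1`, is not yet measured in this assay. It differs from compound 2 by (morpholin-4-yl)carbonyl in place of (pyrrolidin-1-yl)methyl on a saturated chain carbon bound to an amide-type nitrogen. For the measured compounds named here, the only measured step bears on it indirectly: it shows that an exchange of the group on the carbonyl-attached nitrogen can move the number by a modest, real amount, but that step concerns a different pair of groups, and no compound with a (morpholin-4-yl)carbonyl has been measured. The change here is larger in atom count and alters the ring type, so some movement is expected, most likely a drift back toward compound 1, while a number within the scatter of compound 2 cannot be excluded.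

Expectation for compound 3: a step of a 2.0-fold higher number from compound 2 to compound 3 (0.30 log units; within the scatter), giving an estimate of 750 nM with a range from 250 nM to 2200 nM.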

Compound 3, half-maximal inhibitory concentration: 630 nM
Beside the measured number, compound 3's estimate is 1.2-fold (0.08 log units) above it, and the stated range covers the measured number.
By their numbers in this assay, from the lowest: compounds 2 and 3 (each within the scatter of the next); then compound 1.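

In this assay, (morpholin-4-yl)carbonyl in place of (pyrrolidin-1-yl)methyl on a saturated chain carbon bound to an amide-type nitrogen gives a 1.7-fold higher number from compound 2 to compound 3 (0.22 log units; within the scatter) and so does not separate the two groups on this read-out, even though they differ in ring size, in hetero atoms and in the added carbonyl. Against dimethylamino on a carbonyl carbon, (((morpholin-4-yl)carbonyl)methyl)amino gives a 2.5-fold lower number from compound 1 to compound 3 (0.39 log units; beyond the scatter), so a step beyond the scatter from compound 1 now holds for two different extended groups rather than for (2-(pyrrolidin-1-yl)ethyl)amino alone. Nothing at hand explains why the two extended groups read alike.

The exchange alters the ring and the carbonyl together, so the contribution of each stays unresolved; (morpholin-4-yl)methyl and (pyrrolidin-1-yl)carbonyl would separate the two changes. Also open, on these data alone, is whether a longer chain on the amide-type nitrogen, or a carboxylic acid in place of the terminal ring, keeps the number within the scatter of compound 2 and compound 3.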